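The source may hold more compounds than are shown below. What is called first, only, known or untested is meant among the compounds shown, and "the series" means these compounds.

Compound 3 `CCCCCCCCCCOC(=O)CC(=O)Nc1c(C(C)C)cccc1C(C)C` stands lowest of the three numbers in an assay on microsomes from intestine for inhibition of acyl-CoA:cholesterol acyltransferase (Oryctolagus cuniculus) (on this read-out higher numbers stand for weaker inhibition and lower numbers for stronger inhibition), where compound 3 gives 53 nM. Compound 1 `COc1cc(OC)c(NC(=O)CC(=O)Oc2c(C(C)C)cccc2C(C)C)c(OC)c1` gives 1000 nM in this assay, and compound 2 `CCOC(=O)CC(=O)Nc1c(C(C)C)cccc1C(C)C` gives 1800 nM. Compound 4 `CCCCCCCCCCCCCCCCCCOC(=O)CC(=O)Nc1c(C(C)C)cccc1C(C)C` has not yet been measured; it differs from compound 3 by octyl in place of hydrogen on a saturated chain carbon, ten or more bonds along the chain from an oxygen next to a carbonyl group. Within the data shown here, one measured step bears on this change, an octyl in place of hydrogen two bonds along the chain from an oxygen next to a carbonyl group: a 34-fold lower number from compound 2 to compound 3 (1.53 log units; beyond the scatter), a large step. Compound 4 is expected to move less, with a step of a 1.3-fold lower number from compound 3 to compound 4 (0.12 log units; within the scatter) estimated as small and downward. Compound 4 is therefore expected to give about 40 nM, within a range of 15 nM to 150 nM.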

Compound 4, half-maximal inhibitory concentration: 53 nM
Beside the measured number, compound 4's estimate is 1.3-fold (0.12 log units) below it, within the range that was stated.
By their numbers in this assay, from the lowest: compounds 3 and 4 (each within the scatter of the next); then compounds 1 and 2 (each within the scatter of the next).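

In this assay, octyl in place of hydrogen on a saturated chain carbon gives no change at the digits printed from compound 3 to compound 4 (within the scatter). The same group placed two bonds along the chain gave a 34-fold lower number from compound 2 to compound 3 (1.53 log units; beyond the scatter), so at this position the large step does not repeat and the number holds once the chain reaches the length of compound 3. Nothing measured here explains this flat step.

Chains of intermediate length between compound 3 and compound 4 remain open. So does the effect of a longer chain, or of a carboxylic acid or an amine at the far end of the chain.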